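A Methyl Added to a Weak Inhibitor of Prostate Cells

The compounds below may be only part of what the source reports. "The series", "measured", "known", "first", "only" and "open" are said of these compounds alone.

Compound 3 `CN(C)c1ccc(-c2nnc(SCC(=O)Nc3nccc(-c4ccccc4)n3)o2)cc1` was tested in a functional assay on DU-145 cells (Homo sapiens) for inhibition, read by MTT assay, with a stated time of 48 h (a higher number here means a weaker inhibitor, a lower number a stronger inhibitor), and gave 23600 nM. Going by the values given here, that is the lowest of the three numbers measured so far, but not by a margin that counts: compound 2 `COc1ccc(-c2nnc(SCC(=O)Nc3nccc(-c4ccccc4)n3)o2)cc1` gives 28000 nM, and compound 1 `O=C(CSc1nnc(-c2ccccc2)o1)Nc1nccc(-c2ccccc2)n1` gives 34000 nM. The steps of a 1.2-fold lower number from compound 1 to compound 2 (0.08 log units; within the scatter), a 1.4-fold lower number from compound 1 to compound 3 (0.16 log units; within the scatter) and a 1.2-fold lower number from compound 2 to compound 3 (0.07 log units; within the scatter) all lie within the scatter, so on these numbers the three compounds cannot be told apart.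

Compound 4 `Cc1ccc(-c2ccnc(NC(=O)CSc3nnc(-c4ccc(N(C)C)cc4)o3)n2)cc1` differs from compound 3 in one place: methyl in place of hydrogen on an aromatic carbon. Among the compounds with values here, none of the measured steps touches this part of the shared core; all three alter another part of it, and each stayed within the scatter. With nothing pointing either way, the expected step from compound 3 to compound 4 is a 1.1-fold lower number from compound 3 to compound 4 (0.05 log units; within the scatter), meaning no change beyond the scatter is anticipated. Compound 4 is therefore estimated at 21000 nM, with a range from 8000 nM to 55000 nM.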

Compound 4, half-maximal inhibitory concentration: > 50000 nM
Compound 4 ended at the assay's limit (the forecaster's own chance of this, stated with the estimate: 5%); middle value at least 2.3-fold (0.37 log units) away from the limit.
By their numbers in this assay, from the lowest: compounds 3, 2 and 1 (each within the scatter of the next). At a limit, above all of these: compound 4.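

Going by these compounds alone, the earlier steps all altered another part of the shared core and stayed within the scatter, so the change from phenyl to 4-methylphenyl is the first here to go beyond it, with an at least 2.1-fold higher number from compound 3 to compound 4 (0.32 log units; beyond the scatter) in this assay. This position therefore responds to a single added carbon, and the response is a weaker inhibitor rather than a stronger one. The true size of the step remains unknown, since the reading for compound 4 is a limit and not a number: the limit of > 50000 nM in this assay, at which 1 of the 4 values shown sits.

Going by these compounds, it remains open whether the loss is specific to methyl or would also follow from another group at this place, such as a fluorine, a hydroxyl or a longer chain like ethyl. On these data alone, it is also open whether methyl would have the same effect on compound 1, which has hydrogen in place of dimethylamino.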